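The source may hold more compounds than are shown below. What is called first, only, known or untested is meant among the compounds shown, and "the series" means these compounds.

Measured in a functional assay on DU-145 cells (Homo sapiens) for inhibition, read by trypan blue exclusion, with a stated time of 96 h; on this read-out lower numbers stand for stronger inhibition of growth and higher numbers for weaker inhibition of growth:
- compound 1 `O=C(/C(=C\c1ccc(Cl)cc1)S(=O)(=O)c1ccc(Br)cc1)c1ccc(Br)cc1`: 50000 nM
- compound 2 `O=C(/C(=C\c1ccc(F)cc1F)S(=O)(=O)c1ccc(Br)cc1)c1ccc(Br)cc1`: 7500 nM

Of these two, compound 2 holds the lower number, at 7500 nM. Compound 3 `O=C(/C(=C\c1ccc(F)cc1Cl)S(=O)(=O)c1ccc(Br)cc1)c1ccc(Br)cc1` differs from it in one place: chloro in place of fluoro on an aromatic carbon. This is chloro in place of fluoro on an aromatic carbon, turning 2,4-difluorophenyl into 2-chloro-4-fluorophenyl.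

Within the data shown here, only one measured step bears on this change, a 6.7-fold lower number from compound 1 to compound 2 (0.82 log units; beyond the scatter). It exchanged 4-chlorophenyl for 2,4-difluorophenyl, so it altered more than one ring substituent at once and does not isolate the swap made here. Among the measured compounds shown here, no measured pair shows chloro and fluoro exchanged at this place. Compound 3 keeps the fluoro group of compound 2 and, like compound 1, carries a chloro group on that ring. In this assay, a small move toward a higher number is therefore expected, smaller than the measured step and perhaps not beyond the scatter. The expected step is a 1.3-fold higher number from compound 2 to compound 3 (0.12 log units; within the scatter). For compound 3 the estimated value is 10000 nM, with an expected range of 3500 nM to 35000 nM.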

Compound 3, concentration for 50% growth inhibition: 50000 nM
For compound 3 the middle estimate is 5.0-fold (0.70 log units) below the measured one, outside the stated range (above it).
By their numbers in this assay, from the lowest: compound 2; then compounds 1 and 3 (each within the scatter of the next).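

In this assay, the exchange of chloro for fluoro on this aromatic carbon, ortho to a large group, proves to be a real step rather than a small adjustment: a 6.7-fold higher number from compound 2 to compound 3 (0.82 log units; beyond the scatter), although the swap replaces one heavy atom with one heavy atom and leaves the counted hydrogen-bond donors and acceptors unchanged. The comparison with the 4-chlorophenyl compound gives no change at the digits printed from compound 1 to compound 3 (within the scatter), so compound 3 keeps a fluoro group yet does not share the lower number of compound 2, which shows that a fluoro group on this ring does not by itself go with that lower number and that the group at this one place matters. Nothing available here explains why this exchange has such an effect.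

The compounds shown leave open how a methyl group, a methoxy group or an amine on this same aromatic carbon would read in this assay. They also leave open whether chloro in place of fluoro would give a step of the same size on another core, or at the other fluoro-bearing carbon of the ring.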